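Swapping an Octyl Chain for a Halogenated Phenyl Ring

The source may report more compounds than this note shows. Statements on the series, on what has been measured and on what is new or still open speak of the compounds shown alone.

Of the compounds shown here, three built on one shared core have been tested in a functional assay on HeLa cells (Homo sapiens) for inhibition, read by MTT assay, with a stated time of 24 h; on this read-out lower numbers stand for stronger inhibition and higher numbers for weaker inhibition. Compound 2 `CCOC(=O)C1=Cc2ccccc2OC1(OCc1cn(CC(=O)Nc2ccccc2F)nn1)C(F)(F)F` gives 49900 nM in this assay. Compound 1 `CCOC(=O)C1=Cc2ccccc2OC1(OCc1cn(CC(=O)Nc2ccccc2Br)nn1)C(F)(F)F` reaches only a limit of the assay, > 150000 nM. Compound 3 `CCCCCCCCn1cc(COC2(C(F)(F)F)Oc3ccccc3C=C2C(=O)OCC)nn1` likewise reaches only a limit, > 150000 nM. The step of an at least 3.0-fold lower number from compound 1 to compound 2 (0.47 log units; beyond the scatter) follows fluoro in place of bromo on an aromatic carbon. The step of an at least 3.0-fold higher number from compound 2 to compound 3 (0.47 log units; beyond the scatter) follows heptyl in place of (2-fluorophenyl)carbamoyl on a saturated chain carbon bound to an aromatic nitrogen, so the plain chain did worse than the aryl-bearing amide. The step that the two limits leave unreadable from compound 1 to compound 3 cannot be read because both values sit at the limit of > 150000 nM in this assay, at which 2 of the 3 values shown sit.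

Compound 4 `CCOC(=O)C1=Cc2ccccc2OC1(OCc1cn(-c2ccc(F)c(Cl)c2)nn1)C(F)(F)F` differs from compound 3 by 3-chloro-4-fluorophenyl in place of octyl on an aromatic nitrogen. Within the data shown here, only the step from compound 2 to compound 3 speaks to this change, and it ran in the unfavourable direction when an aryl-bearing group was lost. Returning an aromatic ring, now joined directly to the ring nitrogen, is therefore expected to lower the number somewhat, giving an estimated at least 1.8-fold lower number from compound 3 to compound 4 (0.27 log units; that floor lies within the scatter), though compound 3 stands at a limit, so the starting point is itself uncertain. Compound 4 is estimated at 80000 nM, with a range from 30000 nM to 200000 nM.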

Compound 4, half-maximal inhibitory concentration: 22700 nM
Estimate against measurement, compound 4: 3.5-fold (0.55 log units) above; measured number below the stated range.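

On this aromatic nitrogen, an aryl group attached directly does what the octyl chain does not: in this assay, 3-chloro-4-fluorophenyl in place of octyl gives an at least 6.6-fold lower number from compound 3 to compound 4 (0.82 log units; beyond the scatter), although both groups carry the same count of heavy atoms. The amide link seen in the earlier aryl compounds is also not needed for measurable inhibition, since replacing the whole ((2-fluorophenyl)carbamoyl)methyl group gives a 2.2-fold lower number from compound 2 to compound 4 (0.34 log units; beyond the scatter), and replacing its bromo counterpart gives an at least 6.6-fold lower number from compound 1 to compound 4 (0.82 log units; beyond the scatter). With all three steps beyond the scatter, compound 4 is the most active of the four compounds shown.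

A single substituted ring cannot show whether the gain comes from the chlorine, the fluorine or the ring itself, and an unsubstituted phenyl, a 4-methoxyphenyl or a chain ending in an amine on this nitrogen would help to separate these. The true sizes of the steps starting from compound 1 and compound 3 also stay open, because both of those compounds rest at a limit rather than at a number: the limit of > 150000 nM in this assay, at which 2 of the 4 values shown sit.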